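This account rests on a few compounds, and the source may have more. Where it says the series, first, only, none or still open, it means among the compounds named here.

Measured so far in a functional assay on M14 cells (Homo sapiens) for cytotoxicity, read by resazurin assay, with a stated time of 72 h; a higher number here means a weaker inhibitor, a lower number a stronger inhibitor:
- compound 1 `O=C(/C=C/c1ccc(OCCCCCO[N+](=O)[O-])c(O)c1)OCCCCCO[N+](=O)[O-]`: > 50000 nM (a limit)
- compound 2 `COc1cc(/C=C/C(=O)OCc2ccc(OCc3c(-c4ccccc4)no[n+]3[O-])cc2)ccc1O`: > 50000 nM (a limit)

Neither entry is a number. In this assay, compound 1 stands at > 50000 nM, which is a limit of the assay. The same holds across the measured set, as shown by the limit of > 50000 nM in this assay, at which 2 of the 2 values shown sit. Among the measured compounds shown here, no measured pair differs in one place, so no measured step gauges the next change.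

Compound 3 `COc1cc(/C=C/C(=O)OCCCCCO[N+](=O)[O-])ccc1OCCCCCO[N+](=O)[O-]` differs from compound 1 by methyl in place of hydrogen on an oxygen on an aromatic ring. This is methyl in place of hydrogen on an oxygen on an aromatic ring, or hydroxy to methoxy. The rest of the structure is unchanged.

The expected step is a number no higher from compound 1 to compound 3 (the limit leaves the size open), which means none beyond the scatter in this assay and no favoured direction. This expectation rests only on compound 1 at > 50000 nM, and a report of compound 3 as a limit is the likeliest outcome. Compound 3 is estimated at 50000 nM, with an expected range of 25000 nM to 100000 nM.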

Compound 3, half-maximal inhibitory concentration: > 50000 nM
Compound 3 was reported as a limit (the forecaster's own chance of this, stated with the estimate: 75%); the middle value lies on the limit itself.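

Compound 1 and compound 3 are both reported as limits in this assay, so the step for hydroxy to methoxy cannot be read: the limit of > 50000 nM in this assay, at which 3 of the 3 values shown sit. The compounds shown leave open what this change does to potency in this assay, as well as whether any compound of this series gives a number there rather than a limit.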